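A few compounds are considered here, and "the series" means these few. Any claim that something is new, unique, unknown or untested is made for them only; others in the source may bear on it.

Working notes on the pyrazolopyridine ketone series. In an assay for binding affinity to dual specificity mitogen-activated protein kinase kinase 4 (Homo sapiens), read by KINOMEscan, tested at 100 nM (on this read-out higher numbers stand for a weaker effect at the one concentration tested and lower numbers for a stronger effect), compound 1 `CCCS(=O)(=O)Nc1ccc(F)c(C(=O)c2n[nH]c3ncc(-c4ccccc4C)cc23)c1F` gives 7%, compound 2 `CCCS(=O)(=O)Nc1ccc(F)c(C(=O)c2n[nH]c3ncc(-c4ccc(C)cc4)cc23)c1F` gives 5.4%, and compound 3 `CCCS(=O)(=O)Nc1ccc(F)c(C(=O)c2n[nH]c3ncc(-c4ccccc4O)cc23)c1F` gives 9%. Compound 3 sits at the top of these three numbers, but the steps of a number 2 percentage points higher from compound 1 to compound 3 (within the scatter) and a number 3.6 percentage points higher from compound 2 to compound 3 (within the scatter) both fall within the scatter, so the three are not separated. Compound 4 `CCCS(=O)(=O)Nc1ccc(F)c(C(=O)c2n[nH]c3ncc(-c4cccc(N)c4)cc23)c1F` is not yet measured; it differs from compound 3 by 3-aminophenyl in place of 2-hydroxyphenyl on an aromatic carbon. For the measured compounds named here, the steps that bear on this change are a number 2 percentage points higher from compound 1 to compound 3 (within the scatter), which swapped one substituent for another, and a number 1.6 percentage points lower from compound 1 to compound 2 (within the scatter), which moved a substituent around the ring; neither left the scatter. Accordingly no step beyond the scatter is expected for this assay, and a number 1 percentage points lower from compound 3 to compound 4 (within the scatter) is the estimated change. Compound 4 is expected to give 8%, within 3% to 16%.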

Compound 4, a percentage reported as activity, at one concentration (the size of the read-out at that concentration, not a potency): 1.6%
Beside the measured number, compound 4's estimate is 6.4 percentage points above it, and the stated range ends above it.
By their numbers in this assay, from the lowest: compounds 4, 2, 1 and 3 (each within the scatter of the next).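

With 3-aminophenyl, a nitrogen-bearing ring enters this position in this assay, and the steps of a number 7.4 percentage points lower from compound 3 to compound 4 (within the scatter) and a number 3.8 percentage points lower from compound 2 to compound 4 (within the scatter) and a number 5.4 percentage points lower from compound 1 to compound 4 (within the scatter) all stay within the scatter. The 2-substituted, 4-substituted and 3-substituted phenyl groups shown are therefore not separated from one another in this read-out. No available data account for these numbers. Still open, from the compounds shown here alone, is whether a carboxylic acid or a longer chain such as aminomethyl on this phenyl ring would leave the scatter. Going by these compounds, a saturated cyclic amine in place of the phenyl ring remains equally open.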